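Methyl Ester to Free Acid on a Shared Lactone Core

The compounds below may be only part of what the source reports. "The series", "measured", "known", "first", "only" and "open" are said of these compounds alone.

Compound 1 `CC(C)[C@H]1CC[C@@]2(CO2)[C@H]2C(=O)OCC(C(=O)OCc3ccc(-c4ccc([N+](=O)[O-])cc4)o3)=C[C@H]12` gives 450 nM in a functional assay on A549 cells (Homo sapiens) for inhibition, with a stated time of 72 h; a higher number here means a weaker inhibitor, a lower number a stronger inhibitor. Compound 3 `COC(=O)C1=C[C@@H]2[C@@H](C(C)C)CC[C@@]3(CO3)[C@H]2C(=O)OC1` gives 450 nM in this assay, level with compound 1 at the digits shown and within the scatter of it. Compound 2 `CC(C)[C@H]1CC[C@@](O)(CO)[C@H]2C(=O)OCC(C(=O)O)=C[C@H]12` in this assay reaches only the limit > 32000 nM, a limit of the assay rather than a number, and it is the value meant by the limit of > 32000 nM in this assay, at which 1 of the 3 values shown sits. Compound 4 `CC(C)[C@H]1CC[C@@]2(CO2)[C@H]2C(=O)OCC(C(=O)O)=C[C@H]12` has not yet been measured in this assay; it differs from compound 3 by hydrogen in place of methyl on an oxygen next to a carbonyl group, the rest of the shared core staying as in compound 3. A weakening beyond the scatter is expected, the step of a 22-fold higher number from compound 3 to compound 4 (1.35 log units; beyond the scatter) being an estimate. Compound 4 is therefore expected to give about 10000 nM in this assay, within a range from 1500 nM to 40000 nM.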

Compound 4, half-maximal inhibitory concentration: 458 nM
The estimate for compound 4 lay 22-fold (1.34 log units) above the measured number; measured number below the stated range.
By their numbers in this assay, from the lowest: compounds 1, 3 and 4 (each within the scatter of the next). At a limit, above all of these: compound 2.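

In this assay the change of methoxycarbonyl to carboxy gives a 1.0-fold higher number from compound 3 to compound 4 (0.01 log units; within the scatter) and so leaves the read-out level at this position. Within the data shown here, a carboxy group here therefore does not by itself carry a loss in this read-out, which the earlier compounds could not show. Compound 2 also bears carboxy and stands at a limit of the assay: the limit of > 32000 nM in this assay, at which 1 of the 4 values shown sits.

The compounds shown leave open whether an amide in place of the carboxy would stay level with compound 3. They also leave open how an ethyl or longer chain on that oxygen would read.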